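Anticonvulsant Cinnamate Esters: From Bromophenyl to Methoxyphenyl

This account rests on a few compounds, and the source may have more. Where it says the series, first, only, none or still open, it means among the compounds named here.

The measured compounds and their values in a functional assay on the whole organism (strain Kunming) with Mus musculus as the target, with a stated time of 0.5 h, at a dose of 300 mg/kg by the intraperitoneal route; a lower number here means a stronger effect, a higher number a weaker effect of the compound at the dose given:
compound 1, `COc1cc(OC)c(OC)cc1/C=C/COC(=O)/C=C/c1ccc(OC)c(OC)c1`: 75%
compound 2, `COc1cc(OC)c(OC)cc1/C=C/COC(=O)/C=C/c1cc(OC)c(OC)c(OC)c1`: 75%
compound 3, `COc1cc(OC)c(OC)cc1/C=C/COC(=O)/C=C/c1cccc(Br)c1`: 50%

Compound 3 stands lowest of the three numbers; its nearest neighbour is compound 1, and compound 2 lies at the same distance from it. Both gaps are beyond the scatter, so compound 3 shows the strongest effect here. Compound 1 and compound 2 sit within the scatter of each other, as no change at the digits printed from compound 1 to compound 2 (within the scatter) shows.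

The unmeasured compound 4, `COc1ccc(/C=C/C(=O)OC/C=C/c2cc(OC)c(OC)cc2OC)cc1`, differs from compound 3 as follows: 4-methoxyphenyl in place of 3-bromophenyl on a double-bonded chain carbon bound to a double-bonded chain carbon.

The measured step that bears on this change is a number 25 percentage points lower from compound 1 to compound 3 (beyond the scatter), where a methoxy-bearing phenyl gave way to the bromophenyl. The change to compound 4 runs the other way, putting a methoxyphenyl back in. The account therefore expects the number to rise again by about the same amount, giving an estimated step of a number 20 percentage points higher from compound 3 to compound 4 (beyond the scatter). For compound 4 the estimated value in this assay is 70%, expected to lie between 50% and 90%.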

Compound 4, a percentage reported as activity, at one dose (the size of the read-out at that dose, not a potency): 100%
Compound 4: the middle estimate sits 30 percentage points below what was measured; measured number above the stated range.
By their numbers in this assay, from the lowest: compound 3; then compounds 1 and 2 (each within the scatter of the next); then compound 4.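

In this assay, exchanging the 3-bromophenyl for 4-methoxyphenyl at this position on the double-bonded chain carbon gives a number 50 percentage points higher from compound 3 to compound 4 (beyond the scatter), so a methoxy-bearing phenyl here does not simply return the number to that of the dimethoxy analogues. The methoxy groups on this ring also prove not to be interchangeable: adding one to compound 1 had left the number unchanged within the scatter, yet replacing one with hydrogen gives a number 25 percentage points higher from compound 1 to compound 4 (beyond the scatter), which shows that this ring's substitution can shift the effect at the given dose in either direction, and that the single 4-methoxyphenyl ranks on the weak side of compound 1. Nothing available here accounts for this difference in terms of any measured property of these groups.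

The step from the 3-bromophenyl to the 4-methoxyphenyl changes both the substituent and where it sits on the ring, so the compounds shown cannot separate these two contributions. They also leave open whether the lower number of compound 3 is particular to bromine or would also be seen with another group on the phenyl, such as chlorine, trifluoromethyl or a nitrile.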